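The compounds below may be only part of what the source reports. "The series", "measured", "known", "first", "only" and "open" are said of these compounds alone.

Compound 1 `COc1cc(C(=O)c2sc(-c3ccc(-c4ccccc4)cc3)cc2N)cc(OC)c1OC`: > 10000 nM, a limit of the assay
Compound 2 `COc1cc(C(=O)c2sc(-c3ccc(I)cc3)cc2N)cc(OC)c1OC`: 190 nM
Compound 3 `COc1cc(C(=O)c2sc(-c3cccc([N+](=O)[O-])c3)cc2N)cc(OC)c1OC`: 7.5 nM

In a functional assay on MOLT-4 cells (Homo sapiens) for antiproliferative activity (a lower number here means a stronger inhibitor, a higher number a weaker inhibitor), compound 3 has the lowest of the numbers, and the step to it is a 25-fold lower number from compound 2 to compound 3 (1.40 log units; beyond the scatter). Compound 4 `COc1cc(C(=O)c2sc(-c3ccccc3)cc2N)cc(OC)c1OC` has hydrogen in place of nitro on an aromatic carbon. For the measured compounds named here, two measured steps bear on this part of the molecule only indirectly, since neither removes nitro alone. Both an at least 52-fold lower number from compound 1 to compound 2 (1.72 log units; beyond the scatter) and a 25-fold lower number from compound 2 to compound 3 (1.40 log units; beyond the scatter) are large, and the first starts from a limit. Compound 2, which has no nitro, gives 190 nM. A moderate rise is therefore expected, an estimated 5.3-fold higher number from compound 3 to compound 4 (0.73 log units; beyond the scatter). The estimate for compound 4 is 40 nM, with an expected range of 8 nM to 250 nM.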

Compound 4, half-maximal inhibitory concentration: 5.3 nM
Beside the measured number, compound 4's estimate is 7.5-fold (0.88 log units) above it; measured number below the stated range.
By their numbers in this assay, from the lowest: compounds 4 and 3 (each within the scatter of the next); then compound 2. At a limit, above all of these: compound 1.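

In this assay, nitro proves dispensable on this ring: hydrogen in its place gives a 1.4-fold lower number from compound 3 to compound 4 (0.15 log units; within the scatter). Against the plain phenyl of compound 4, iodo and phenyl both count as large losses, with a 36-fold lower number from compound 2 to compound 4 (1.55 log units; beyond the scatter) and an at least 1800-fold lower number from compound 1 to compound 4 (3.27 log units; beyond the scatter). Compound 1 stands at a limit and not at a number: the limit of > 10000 nM in this assay, at which 1 of the 4 values shown sits.

On these data alone, whether an amine or a methoxy group in the place of nitro would also stay level with hydrogen remains open. So does whether nitro would be tolerated where iodo sits in compound 2, since the iodo and nitro groups occupy different places.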